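The source may report more compounds than this note shows. Statements on the series, on what has been measured and on what is new or still open speak of the compounds shown alone.

In an assay on isolated protein for inhibition of protein deacetylase HDAC6 (Homo sapiens), with a stated time of 60 min (a higher number here means a weaker inhibitor, a lower number a stronger inhibitor), compound 1 `O=C(CCCCCn1cc(Nc2ncc3ccn(Cc4ccccc4)c3n2)cn1)NO` gives 13.8 nM, and compound 2 `O=C(CCCCCn1cc(Nc2ncc3ccn(Cc4ccccc4Cl)c3n2)cn1)NO` gives 45 nM, the higher of the two numbers measured; the step of a 3.3-fold higher number from compound 1 to compound 2 (0.51 log units; beyond the scatter) is modest but lies beyond the scatter. Compound 3 `O=C(CCCCCn1cc(Nc2ncc3ccn(Cc4cccc(Cl)c4)c3n2)cn1)NO` differs from compound 2 by 3-chlorophenyl in place of 2-chlorophenyl on a saturated chain carbon bound to an aromatic nitrogen. For the measured compounds named here, no measured step covers this rearrangement itself; only the addition of chloro that leads to compound 2 bears on it, and that raised the number modestly. A step of comparable size in either direction, or none beyond the scatter, is therefore expected. Compound 3 is expected to give 30 nM, within 12 nM to 80 nM, a step of a 1.5-fold lower number from compound 2 to compound 3 (0.18 log units; within the scatter) in this assay.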

Compound 3, half-maximal inhibitory concentration: 34.4 nM
The estimate for compound 3 lay 1.1-fold (0.06 log units) below the measured number; low and high end bracket the measured number.
By their numbers in this assay, from the lowest: compound 1; then compounds 3 and 2 (each within the scatter of the next).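

In this assay, 3-chlorophenyl in place of 2-chlorophenyl on a saturated chain carbon bound to an aromatic nitrogen gives a 1.3-fold lower number from compound 2 to compound 3 (0.12 log units; within the scatter) and so leaves the two placements of chloro indistinguishable here. Against compound 1, the chloro compound still shows a 2.5-fold higher number from compound 1 to compound 3 (0.40 log units; beyond the scatter) as a step beyond the scatter, so the higher number seen with chloro is not confined to 2-chlorophenyl. No measurement shown here accounts for this. On these data alone, whether methoxy or an amine on the same phenyl ring would give a similar number remains open.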